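Adding chloro to compound 2: working notes on growth inhibition

A few compounds are considered here, and "the series" means these few. Any claim that something is new, unique, unknown or untested is made for them only; others in the source may bear on it.

Values from a functional assay on NCI-H460 cells (Homo sapiens) for inhibition (a higher number here means a weaker inhibitor of growth, a lower number a stronger inhibitor of growth), follow
- compound 1 `Nc1ccc(-c2nc3ccc(F)cc3s2)cc1I` gives > 100000 nM (a limit of the assay, not a number)
- compound 2 `Nc1ccc(-c2nc3cc(F)ccc3s2)cc1` gives 870 nM
- compound 3 `Nc1ccc(-c2nc3ccc(F)cc3s2)cc1Cl` gives 100 nM

Compound 2 (870 nM) holds the higher of the two true numbers in this assay, and compound 3 (100 nM) lies lower by more than the scatter.

The change chloro in place of hydrogen on an aromatic carbon leads from compound 2 to the unmeasured compound 4 `Nc1ccc(-c2nc3cc(F)ccc3s2)cc1Cl` and places chloro ortho to an amino group. Among the measured compounds shown here, no measured step is this exact change. The only one available is large (an at least 1000-fold lower number from compound 1 to compound 3 (3.00 log units; beyond the scatter)), and it exchanges iodo for chloro, not hydrogen for chloro. Its size also rests on a limit (the limit of > 100000 nM in this assay, at which 1 of the 3 values shown sits), so it gives no true measure of a step. Compound 3 (100 nM) carries the chloro but differs from compound 2 in more than that group, so it hints at a direction only. A moderate step towards a lower number is therefore expected, well short of the large step above.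

The expected move is a 2.9-fold lower number from compound 2 to compound 4 (0.46 log units; beyond the scatter) in this assay (an estimate, with wide uncertainty). Compound 4 is expected at 300 nM (estimated range 60 nM to 1500 nM).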

Compound 4, concentration for 50% growth inhibition: 40 nM
Compound 4: the middle estimate sits 7.5-fold (0.88 log units) above what was measured; the whole stated range lies above it.
By their numbers in this assay, from the lowest: compound 4; then compound 3; then compound 2. At a limit, above all of these: compound 1.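

In this assay, the change from hydrogen to chloro on this aromatic carbon, ortho to an amino group and meta to a large group, gives a 22-fold lower number from compound 2 to compound 4 (1.34 log units; beyond the scatter). A single chlorine, the only heavy atom added, is thus enough to move the number well beyond the scatter at this position, and the step is large in its own right, not merely a hint of direction. This is also the first step in the series that involves chloro and joins two true numbers, whereas compound 1 stands at a limit and the earlier step ending at compound 3 gives no true size: the limit of > 100000 nM in this assay, at which 1 of the 4 values shown sits.

Among the compounds shown here, the series holds only this one hydrogen-to-chloro pair, so it remains open whether the size of the step belongs to chloro itself or would also appear with bromo, methyl, methoxy or trifluoromethyl on the same carbon. As far as these compounds go, it is equally open whether the step would persist if the neighbouring amino group gave way to a hydroxyl or an acetamide, or with the fluoro group moved elsewhere on the core.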